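This account rests on a few compounds, and the source may have more. Where it says the series, first, only, none or still open, it means among the compounds named here.

Among the three compounds measured so far, compound 3 `CC(C)Sc1nc(N)nc2c1ncn2[C@@H]1O[C@H](CO)[C@@H](O)[C@H]1O` stands highest: in an assay on isolated protein for binding affinity to Equilibrative nucleoside transporter 1 (Homo sapiens) (a lower number here means a stronger inhibitor, a higher number a weaker inhibitor), compound 3 gives 191000 nM. Compound 1 `Nc1nc(SCc2cccc(Br)c2)c2ncn([C@@H]3O[C@H](CO)[C@@H](O)[C@H]3O)c2n1` gives 2880 nM in this assay, and compound 2 `Nc1nc(SI)c2ncn([C@@H]3O[C@H](CO)[C@@H](O)[C@H]3O)c2n1` gives 81300 nM. Compound 4 `CC(=O)c1ccccc1Sc1nc(N)nc2c1ncn2[C@@H]1O[C@H](CO)[C@@H](O)[C@H]1O` is not yet measured; it differs from compound 3 by 2-acetylphenyl in place of isopropyl on a sulfur. Within the data shown here, two measured steps bear on this change. The step of a 66-fold higher number from compound 1 to compound 3 (1.82 log units; beyond the scatter) shows that a group carrying an aromatic ring on the sulfur, against isopropyl, went with a far lower number, while a 2.3-fold higher number from compound 2 to compound 3 (0.37 log units; beyond the scatter) was modest. Because a 66-fold higher number from compound 1 to compound 3 (1.82 log units; beyond the scatter) was large, a clearly lower number is expected for compound 4, though 2-acetylphenyl is not the same group as 3-bromobenzyl, so the full size of that step is not assumed. The step estimated in this assay for compound 4 is a 16-fold lower number from compound 3 to compound 4 (1.20 log units; beyond the scatter). Compound 4 is estimated at 12000 nM, with a range from 2500 nM to 60000 nM.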

Compound 4, half-maximal inhibitory concentration: 447000 nM
Compound 4: the middle estimate sits 37-fold (1.57 log units) below what was measured; the whole stated range lies below it.
By their numbers in this assay, from the lowest: compound 1; then compound 2; then compound 3; then compound 4.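

A ring on the sulfur does not by itself go with a lower number: 2-acetylphenyl gives a 2.3-fold higher number from compound 3 to compound 4 (0.37 log units; beyond the scatter) and a 5.5-fold higher number from compound 2 to compound 4 (0.74 log units; beyond the scatter). Compound 1 alone stands apart, shown by a 160-fold higher number from compound 1 to compound 4 (2.19 log units; beyond the scatter), so the ring-bearing group's identity matters here, not merely the ring's presence. Nothing measured here explains this difference.

Going by these compounds, it remains open whether the bromine, the acetyl group or the extra carbon of the benzyl group accounts for the gap. Plain phenyl and plain benzyl on the sulfur would help separate these features.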